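This account rests on a few compounds, and the source may have more. Where it says the series, first, only, none or still open, it means among the compounds named here.

Measured in a functional assay on K562 cells (Homo sapiens) for antiproliferative activity, read by MTT assay, with a stated time of 48 h; on this read-out lower numbers stand for stronger inhibition of growth and higher numbers for weaker inhibition of growth:
- compound 1 `CCOc1cc(NC(=O)CCCCCCC(=O)Nc2cc(-c3ccccc3)ccc2N)cc2c1OCC([N+](=O)[O-])=C2`: 2000 nM
- compound 2 `CCOc1cc(NC(=O)CCCCCCC(=O)Nc2ccccc2N)cc2c1OCC([N+](=O)[O-])=C2`: 3360 nM

Compound 2 stands at 3360 nM, within the scatter of compound 1, so the two values give no order.

Next in the series is compound 3 `CCOc1cc(NC(=O)CCCCCNC(=O)CCCc2ccccc2)cc2c1OCC([N+](=O)[O-])=C2`, not yet measured in this assay. The change from compound 2 is ((3-phenylpropyl)carbonyl)amino in place of ((2-aminophenyl)carbamoyl)methyl on a saturated chain carbon, five bonds along the chain from a carbonyl carbon.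

For the measured compounds named here, only one measured step bears on this, and only loosely: a 1.7-fold higher number from compound 1 to compound 2 (0.23 log units; within the scatter), with hydrogen in place of phenyl on an aromatic carbon. That step alters the aromatic ring of the leaving group but keeps the group itself. Going by the values given here, the data therefore hold no measure of removing it, and compound 3 has no close measured analogue. A modest move towards a higher number is tentatively expected, though a result within the scatter would not surprise.

The expected change is a 1.5-fold higher number from compound 2 to compound 3 (0.17 log units; within the scatter).

For compound 3 the estimated value is 5000 nM, with an expected range of 1500 nM to 20000 nM.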

Compound 3, concentration for 50% growth inhibition: 3320 nM
Beside the measured number, compound 3's estimate is 1.5-fold (0.18 log units) above it; the measured number falls inside the stated range.
By their numbers in this assay, from the lowest: compounds 1, 3 and 2 (each within the scatter of the next).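

In this assay, replacing the ((2-aminophenyl)carbamoyl)methyl group with ((3-phenylpropyl)carbonyl)amino at this position, on a saturated chain carbon, five bonds along the chain from a carbonyl carbon, gives a 1.0-fold lower number from compound 2 to compound 3 (0.01 log units; within the scatter). The earlier step altered only the aromatic ring of the leaving group, whereas this one removes the group whole: 11 heavy atoms with 2 hydrogen-bond donors and 2 hydrogen-bond acceptors give way to 12 heavy atoms with 1 hydrogen-bond donor and 1 hydrogen-bond acceptor, and the two compounds still stand within the scatter of each other, so on this read-out the position tolerates this exchange with the shared core unchanged. No measurement at hand explains why the two groups read alike.

As far as these compounds go, whether that tolerance extends to a free amine, a carboxylic acid or a longer chain at this position remains open, since only these two kinds of chain end appear here. Also open, from the compounds shown here alone, is whether a simple methyl group in this place would read the same, which would show how much any aromatic chain end matters.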